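Trifluoroacetyl series: changing the aniline on compound 2

A few compounds are considered here, and "the series" means these few. Any claim that something is new, unique, unknown or untested is made for them only; others in the source may bear on it.

Measured values, all from (a functional assay on HepG2 cells (Homo sapiens) for antiproliferative activity, read by MTT assay, with a stated time of 48 h; a higher number here means a weaker inhibitor, a lower number a stronger inhibitor)
- compound 1 `COc1ccc(-c2c(Nc3ccc(C)cc3)c3ccc(O)cc3oc2=O)cc1` gives 88300 nM
- compound 2 `COc1ccc(Nc2c(C(=O)C(F)(F)F)c(=O)oc3ccc(OC)cc23)cc1` gives > 100000 nM

Compound 2 has no numerical value: its reading of > 100000 nM is a limit of the assay. It therefore sits at the limit of > 100000 nM in this assay, at which 1 of the 2 values shown sits, and gives no exact starting point. Compound 3 `COc1ccc2oc(=O)c(C(=O)C(F)(F)F)c(Nc3ccc(C)c(O)c3)c2c1` has yet to be measured. It carries 3-hydroxy-4-methylphenyl in place of 4-methoxyphenyl on a nitrogen on an aromatic ring. Within the data shown here, no measured pair shows what this change does, so only a small shift towards stronger inhibition in this assay is expected, and none beyond the scatter remains possible. Among the measured compounds shown here, compound 1 at 88300 nM is the only numerical reading, so the expectation stays near that level. Compound 3 is estimated at 60000 nM, with an expected range of 15000 nM to 100000 nM. This estimate means an expected step of an at least 1.6-fold lower number from compound 2 to compound 3 (0.22 log units; that floor lies within the scatter) in this assay.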

Compound 3, half-maximal inhibitory concentration: 6710 nM
Compound 3: the middle estimate sits 8.9-fold (0.95 log units) above what was measured; the measured number lies below the stated range.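

In this assay, 3-hydroxy-4-methylphenyl in place of 4-methoxyphenyl on a nitrogen on an aromatic ring gives an at least 14-fold lower number from compound 2 to compound 3 (1.17 log units; beyond the scatter), so the group at this position can move the reading well beyond the scatter. The two groups have the same heavy atoms in number and kind, and the count differs only in the hydrogen-bond donor that 3-hydroxy-4-methylphenyl brings. Compound 2 gives only a limit, so the step is a floor and its true size stays unknown: the limit of > 100000 nM in this assay, at which 1 of the 3 values shown sits.

The hydroxy and methyl groups enter together while the methoxy group leaves, so the compounds shown do not separate their contributions. Also open, from the compounds shown here alone, is how a phenyl ring carrying only the hydroxy group, or an amine or carboxylic acid in place of the hydroxy group, would read.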